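The source may hold more compounds than are shown below. What is called first, only, known or untested is meant among the compounds shown, and "the series" means these compounds.

Measured so far:
compound 1, `O=C(O)c1cnc2n(c1=O)CCC/C2=N\Nc1ccccc1`: > 100 umol/kg
compound 2, `CC1CC/C(=N\Nc2ccccc2Br)c2ncc(C(=O)O)c(=O)n21`: > 320 umol/kg

Both entries in a functional assay on the whole organism for inhibition, with Rattus norvegicus as the target (on this read-out higher numbers stand for an effect only at larger amounts of compound and lower numbers for an effect already at smaller amounts), are limits of the assay, not numbers. Compound 1 sits at the limit of > 100 umol/kg in this assay, at which 1 of the 2 values shown sits. Compound 2 sits at the limit of > 320 umol/kg in this assay, at which 1 of the 2 values shown sits. For the measured compounds named here, compound 2 therefore stands at a limit, and the one further value shown is a limit too, so no step between measured compounds can be sized and nothing is known about how changes on the phenyl ring move the read-out.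

Compound 3, `COc1ccccc1N/N=C1\CCC(C)n2c1ncc(C(=O)O)c2=O`, differs from compound 2 by methoxy in place of bromo on an aromatic carbon. Going by the values given here, with no measured step to lean on, for compound 3 the step is expected to be a number no higher from compound 2 to compound 3 (the limit leaves the size open), none beyond the scatter. Compound 3 is estimated at 320 umol/kg, with a range from 100 umol/kg to 1000 umol/kg, and it is expected that this assay most likely reports only a limit again.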

Compound 3, dose for 50% inhibition: > 1000 umol/kg
Compound 3 was reported as a limit (the forecaster's own chance of this, stated with the estimate: 75%); at least 3.1-fold (0.49 log units) between middle value and limit.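

In this assay compound 3 gives > 1000 umol/kg, a limit and not a number. Compound 2 also stands at a limit, and the step between compound 2 and compound 3 cannot be read. The compounds shown leave open how far any change on the phenyl ring moves the read-out.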